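The compounds below may be only part of what the source reports. "The series", "measured", "known", "first", "only" and "open" are said of these compounds alone.

Two compounds built on the same shared core carry measurements in a functional assay on HT-29 cells (Homo sapiens) for cytotoxicity; on this read-out higher numbers stand for weaker inhibition and lower numbers for stronger inhibition. Compound 1, `Nc1[nH]nc2nnc(-c3ccccn3)c(-c3ccccn3)c12`, gives in this assay a value of 73000 nM. Compound 2, `Nc1nn(COCCO)c2nnc(-c3ccccc3)c(-c3ccccc3)c12`, is reported in this assay only as a limit of > 100000 nM. Compound 2 therefore stands at the limit of > 100000 nM in this assay, at which 1 of the 2 values shown sits, with no finite number of its own. The unmeasured compound 3, `Nc1nn(CCOCCO)c2nnc(-c3ccccc3)c(-c3ccccc3)c12`, differs from compound 2 in a single place: (2-hydroxyethoxy)methyl in place of 2-hydroxyethoxy on a saturated chain carbon bound to an aromatic nitrogen. No measured step in this assay joins two compounds that differ in one place, so nothing among these numbers shows how such a lengthening of the chain moves the read-out. The step from compound 2 to compound 3 is therefore expected to amount to a step that the limit leaves unreadable from compound 2 to compound 3, nothing beyond the usual scatter. Compound 3 is estimated at 150000 nM in this assay, between 60000 nM and 400000 nM, and it may well again be returned only as a limit.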

Compound 3, half-maximal inhibitory concentration: > 100000 nM
Compound 3: no number, only a limit; the forecaster's own chance of this, stated with the estimate: 70%; the middle value does not contradict the limit.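

Among these compounds, compound 3 is reported in this assay with > 100000 nM as a limit and no number of its own, so no step from compound 2 to compound 3 can be read: the limit of > 100000 nM in this assay, at which 2 of the 3 values shown sit. The compounds shown leave open whether lengthening this chain moves the read-out at all.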